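Aryl replacement on a pair at the growth-inhibition limit

The source may hold more compounds than are shown below. What is called first, only, known or untested is meant among the compounds shown, and "the series" means these compounds.

Compound 1 `Cc1ccc(Nc2ncc(C(F)(F)F)c(N3Cc4cccc(N(C)S(C)(=O)=O)c4C3)n2)cc1C`: in a functional assay on A549 cells (Homo sapiens) for antiproliferative activity, read by spectrophotometry, with a stated time of 2 days (a lower number here means a stronger inhibitor of growth, a higher number a weaker inhibitor of growth), compound 1 gives > 30000 nM, a limit of the assay.
Compound 2 `COc1ccc(C(F)(F)F)cc1Nc1ncc(C(F)(F)F)c(N2Cc3cccc(N(C)S(C)(=O)=O)c3C2)n1`: in this assay compound 2 gives > 30000 nM, a limit of the assay.

Compound 1 stands only at a limit, as does every value shown: the limit of > 30000 nM in this assay, at which 2 of the 2 values shown sit. Among the measured compounds shown here, the one measured step, a step that the two limits leave unreadable from compound 1 to compound 2, is therefore unreadable in size. Compound 3 `CN(c1cccc2c1CN(c1nc(Nc3cccc(C(F)(F)F)c3)ncc1C(F)(F)F)C2)S(C)(=O)=O` differs from compound 1 by 3-(trifluoromethyl)phenyl in place of 3,4-dimethylphenyl on a nitrogen on an aromatic ring. For the measured compounds named here, no measured step bears readably on this change, so no direction can be taken from the data. Compound 3 is expected to remain at or near the limit, with an estimated step of a number no higher from compound 1 to compound 3 (the limit leaves the size open). The estimate for compound 3 is 30000 nM, range 8000 nM to 100000 nM.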

Compound 3, concentration for 50% growth inhibition: > 30000 nM
Compound 3 was reported as a limit; the forecaster's own chance of this, stated with the estimate: 75%; the middle value sits exactly at the limit.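

Among the compounds shown here, compound 3 gives > 30000 nM in this assay, a limit of the assay, and no step linking compound 1, compound 2 and compound 3 can be read. As far as these compounds go, whether any aryl replacement on the shared core gives a measurable growth-inhibition value stays open.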